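Half-life notes: piperidin-1-yl to 4-isopropylpiperidin-1-yl

A few compounds are considered here, and "the series" means these few. Any claim that something is new, unique, unknown or untested is made for them only; others in the source may bear on it.

In an ADME assay on microsomes from liver (Homo sapiens) for metabolic stability, with a stated time of 30 min, tested at 1 uM (a lower number here means that the compound disappears faster, a higher number that the compound lasts longer), compound 1 `COc1ccc2[nH]c(C(=O)N3CC(=O)N(Cc4ccccc4)[C@@H](CN4CCCCC4)C3)cc2c1` gives 0.283 h, the higher of the two numbers available, while compound 2 `COc1cccc(CN2C(=O)CN(C(=O)c3cc4cc(OC)ccc4[nH]3)C[C@@H]2c2ccccc2)c1` gives 0.118 h, a gap beyond the usual scatter. Compound 3 `COc1ccc2[nH]c(C(=O)N3CC(=O)N(Cc4ccccc4)[C@@H](CN4CCC(C(C)C)CC4)C3)cc2c1` departs from compound 1 in one place: isopropyl in place of hydrogen on a saturated ring carbon. For the measured compounds named here, no measured pair covers this change, so the expectation is tentative. The expected step of a 1.6-fold lower number from compound 1 to compound 3 (0.20 log units; within the scatter) points downward in this assay, at about the size of the scatter. For compound 3 the estimated half-life is 0.18 h, with an expected range of 0.08 h to 0.4 h.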

Compound 3, half-life: 0.317 h
For compound 3 the middle estimate is 1.8-fold (0.25 log units) below the measured one; the measured number falls inside the stated range.
By their numbers in this assay, from the lowest: compound 2; then compounds 1 and 3 (each within the scatter of the next).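

In this assay, for the compounds shown here, going from piperidin-1-yl to 4-isopropylpiperidin-1-yl gives a 1.1-fold higher number from compound 1 to compound 3 (0.05 log units; within the scatter) as the first reading at this position. Isopropyl in place of hydrogen on a saturated ring carbon, three ring bonds from the ring nitrogen, thus leaves the half-life indistinguishable from that of compound 1. No available evidence bears on this result.

Open, from the compounds shown here alone, is whether a hydroxyl group or a carboxylic acid on the same ring carbon would read the same way. Going by these compounds, a methyl group or a longer chain there also remains open.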